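This account rests on a few compounds, and the source may have more. Where it says the series, first, only, none or still open, it means among the compounds named here.

Measured so far:
- compound 1, `Cc1ccc(-c2cc(-c3ccccc3)nc(SCC(=O)Nc3cccc(C)c3)c2C#N)cc1`: 100000 nM
- compound 2, `Cc1ccc(-c2cc(-c3ccccc3)nc(S[C@H](C)C(=O)Nc3cccc(Cl)c3)c2C#N)cc1`: 100000 nM

In an ADME assay on MDCK cells (Canis lupus familiaris) for cytotoxicity (on this read-out lower numbers stand for higher toxicity in this test and higher numbers for lower toxicity in this test), compound 1 gives 100000 nM. In this assay compound 2 gives 100000 nM. Compound 2 stands level with compound 1 at the digits shown; the two values lie within the scatter of each other, so no order between them can be stated. Both sit at the top of the range that this test has returned here.

The next compound is compound 3, `Cc1ccc(-c2cc(-c3ccccc3)nc(SCC(=O)Nc3cccc(Cl)c3)c2C#N)cc1`. It differs from compound 2 in one place: hydrogen in place of methyl on a saturated chain carbon bound to a carbonyl carbon and a sulfur. The change is small, a single carbon on the saturated chain between the sulfur and the carbonyl, and no ring, donor, acceptor or charge moves with it. Among the compounds with values here, nothing among the measured pair points to this chain carbon mattering for the read-out, since compound 1 and compound 2 already bracket a related difference without a change in the numbers.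

The step from compound 2 to compound 3 in this assay is expected to be none beyond the scatter, no change at the digits printed from compound 2 to compound 3 (within the scatter). For compound 3 the estimate in this assay is 100000 nM, with a range from 50000 nM to 100000 nM, most likely again returned as a limit rather than a number.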

Compound 3, half-maximal cytotoxic concentration: 100000 nM
The estimate for compound 3 equals the measured number at the digits printed; the range from low to high includes it.
By their numbers in this assay, from the lowest: compounds 1, 2 and 3 (each within the scatter of the next).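

In this assay, hydrogen in place of methyl on a saturated chain carbon bound to a carbonyl carbon and a sulfur gives no change at the digits printed from compound 2 to compound 3 (within the scatter). Within the data shown here, this is the first single-place reading at this chain carbon. Compound 1 and compound 2 differ in more than one place and give no such reading. Chloro in place of methyl on an aromatic carbon adds a second single-place reading, with no change at the digits printed from compound 1 to compound 3 (within the scatter). Neither change separates the compounds in this read-out, and no supporting data bear on either result.

Still open, going by these compounds, is whether a larger group on the same saturated chain carbon, such as a longer chain, an amine or a carboxylic acid, would shift the value in this assay. The same question stands for the aromatic carbon that carries chloro or methyl, where a hydroxyl or an amine would test whether this position can move the read-out at all, and for the mirror-image form of the methyl-bearing chain carbon in compound 2.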